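A new aryl group on the amide-type nitrogen

The compounds below may be only part of what the source reports. "The series", "measured", "known", "first", "only" and "open" are said of these compounds alone.

Measured compounds:
compound 1, `CC1SC(c2cccc(C(=O)NCCCCc3ccccc3)c2)N(c2ccc(C3CC3)cc2)C1=O`: 191 nM
compound 2, `COc1ccc(C)cc1N1C(=O)CSC1c1cccc(C(=O)NCCCCc2ccccc2)c1`: 300 nM

Both were tested in a functional assay on HOS-TE85 cells (Homo sapiens) for inhibition, read by CCK-8 assay, with a stated time of 72 h; a lower number here means a stronger inhibitor, a higher number a weaker inhibitor. Compound 2 holds the highest of the two numbers, but its nearest neighbour, compound 1, differs from it only within the scatter, so the two cannot be ordered. Compound 3, `C#Cc1cccc(N2C(=O)CSC2c2cccc(C(=O)NCCCCc3ccccc3)c2)c1`, has not been measured; it carries 3-ethynylphenyl in place of 2-methoxy-5-methylphenyl on an amide-type nitrogen in a ring. With no measured step available to weigh this change, the two known values offer no reason to expect a shift beyond the scatter in this assay. The step of a 1.2-fold lower number from compound 2 to compound 3 (0.08 log units; within the scatter) is expected to stay within the scatter. Compound 3 is therefore estimated at 250 nM, within 80 nM to 800 nM.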

Compound 3, half-maximal inhibitory concentration: 149 nM
Beside the measured number, compound 3's estimate is 1.7-fold (0.22 log units) above it; the range from low to high includes it.
By their numbers in this assay, from the lowest: compounds 3, 1 and 2 (each within the scatter of the next).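

In this assay the step at this position (a 2.0-fold lower number from compound 2 to compound 3 (0.30 log units; within the scatter)) shows that 3-ethynylphenyl can replace 2-methoxy-5-methylphenyl on the amide-type nitrogen in a ring without a difference that stands clear of the scatter. The entering group has no oxygen and adds a triple bond, so the oxygen of the leaving group is not needed for a value in this range. No measurement bears on why the two groups give such similar numbers. On these data alone, it remains open whether a phenyl ring bearing an amine or a carboxylic acid would also stay within the scatter.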